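This account rests on a few compounds, and the source may have more. Where it says the series, first, only, none or still open, it means among the compounds named here.

Compound 2, with the structure `CC(C)CCNCCN(C(=O)[C@@H]1C[C@H]1c1ccccc1)c1ccc(-c2ccccc2)cc1`, gives 5.1 nM in a functional assay for agonist activity at G protein-coupled receptor 88 (Homo sapiens), read by HTRF and cAMP accumulation; a lower number here means that less compound is needed, a higher number that more compound is needed for the effect. Among the compounds with values here, that is the lower of the two numbers measured so far, but its step from compound 1, built as `O=C([C@@H]1C[C@H]1c1ccccc1)N(CC1CCCNC1)c1ccc(-c2ccccc2)cc1` and giving 10 nM, is a 2.0-fold lower number from compound 1 to compound 2 (0.29 log units; within the scatter), so the two compounds cannot be ranked against each other. Compound 3, with the structure `CCC(C)CNCCN(C(=O)[C@@H]1C[C@H]1c1ccccc1)c1ccc(-c2ccccc2)cc1`, is the next compound to be measured. It is built from the same atoms as compound 2, joined differently: sec-butyl in place of isobutyl on a saturated chain carbon bound to an amine nitrogen. Within the data shown here, the only measured step concerns a different place on the shared core and was itself within the scatter, so nothing measured here speaks directly to a rearranged four-carbon chain on the amine. The expectation is therefore a step no larger than the scatter, in no particular direction, and for compound 3 the estimate in this assay is 6 nM, within the range 2 nM to 18 nM, which means a step of a 1.2-fold higher number from compound 2 to compound 3 (0.07 log units; within the scatter).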

Compound 3, half-maximal effective concentration: 4.7 nM
Beside the measured number, compound 3's estimate is 1.3-fold (0.11 log units) above it; measured number inside the range.
By their numbers in this assay, from the lowest: compounds 3, 2 and 1 (each within the scatter of the next, the first and the last beyond it).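

Putting sec-butyl in place of isobutyl on a saturated chain carbon bound to an amine nitrogen gives a 1.1-fold lower number from compound 2 to compound 3 (0.04 log units; within the scatter), so in this assay the two arrangements of this four-carbon chain cannot be told apart. With ((2-methylbutyl)amino)methyl in place of piperidin-3-yl, the data show a 2.1-fold lower number from compound 1 to compound 3 (0.33 log units; beyond the scatter), a modest step and the first one here to pass beyond the scatter, yet it only just clears a line that compound 2, indistinguishable from compound 3, does not. No supporting measurement is available to explain either result.

Both chains shown hold four carbons in a branched arrangement, so it remains open whether a longer chain such as n-hexyl would give a similar number. As far as these compounds go, a ring such as cyclohexyl in the same place is equally open.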